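Series notes: cytotoxicity of four related compounds

The source may report more compounds than this note shows. Statements on the series, on what has been measured and on what is new or still open speak of the compounds shown alone.

Measured so far, in a functional assay on LM7 cells (Homo sapiens) for cytotoxicity, read by MTT assay, with a stated time of 72 h; on this read-out higher numbers stand for weaker inhibition and lower numbers for stronger inhibition:
compound 1 `O=c1cc(CSc2nc3ccccc3s2)oc2ccccc12`: > 25000 nM
compound 2 `O=c1cc(CSc2nc3ccccc3s2)oc2ccc(Cl)cc12`: > 25000 nM
compound 3 `Cc1nnc(SCc2cc(=O)c3cc(Cl)ccc3o2)o1`: > 25000 nM

Compound 1 reaches only a limit of this assay, so its value is not a number. Compound 2 likewise sits at the limit. Compound 3 also gives a limit rather than a number. All three therefore share (the limit of > 25000 nM in this assay, at which 3 of the 3 values shown sit).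

The change from compound 2 to compound 1 is hydrogen in place of chloro on an aromatic carbon. Its size is a step that the two limits leave unreadable from compound 2 to compound 1, since both ends are limits. How the core of compound 3 differs from the core of compound 2 is not broken down here.

Compound 4 `Cc1nnc(SCc2cc(=O)c3ccccc3o2)o1` is not yet measured in this assay. It differs from compound 3 by hydrogen in place of chloro on an aromatic carbon, the same change that was made from compound 2 to compound 1. Because the limit of > 25000 nM in this assay, at which 3 of the 3 values shown sit, holds for every compound shown, the most likely outcome for compound 4 is that it is expected to stay at the limit as well. The step from compound 3 to compound 4 is estimated at a step that the limit leaves unreadable from compound 3 to compound 4, resting on a step that the two limits leave unreadable from compound 2 to compound 1. Compound 4 is thus expected to give about 30000 nM, in the range 10000 nM to 100000 nM.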

Compound 4, half-maximal inhibitory concentration: > 25000 nM
Compound 4 ended at the assay's limit; the forecaster's own chance of this, stated with the estimate: 85%; the middle value is on the limit's open side.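

Compound 3 and compound 4 both sit at a limit in this assay, so no step can be read between them and the exchange of chloro for hydrogen has no readable size. All four compounds share one limit: the limit of > 25000 nM in this assay, at which 4 of the 4 values shown sit.

The compounds shown leave open whether chloro or hydrogen at this place makes any difference to cytotoxicity.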